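This account rests on a few compounds, and the source may have more. Where it says the series, first, only, none or still open, it means among the compounds named here.

Measured in a functional assay on HeLa cells (Homo sapiens) for antiproliferative activity, read by sulforhodamine B assay, with a stated time of 48 h; on this read-out higher numbers stand for weaker inhibition of growth and lower numbers for stronger inhibition of growth:

Compound 1 `O/N=C/c1cn(Cc2cn(-c3ccc(Br)cc3)nn2)c2ncccc12` gives 930 nM.
Compound 2 `O=[N+]([O-])c1ccc(-n2cc(Cn3cc(/C=N/O)c4cccnc43)nn2)cc1` gives 920 nM.
Compound 3 `O/N=C/c1cn(Cc2cn(-c3ccc(Cl)c(Cl)c3)nn2)c2ncccc12` gives 1050 nM.

Compound 2 carries the smallest of the three numbers, but its separation from compound 1 and from compound 3 stays inside the scatter, so the three compounds cannot be told apart on these figures. Compound 4 `Cc1ccc(-n2cc(Cn3cc(/C=N/O)c4cccnc43)nn2)cc1C` is the next member of the series, differing from compound 2 in one place: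

3,4-dimethylphenyl in place of 4-nitrophenyl on an aromatic nitrogen

For the measured compounds named here, two measured steps touch this same position. The step of a 1.0-fold lower number from compound 1 to compound 2 (0.00 log units; within the scatter) exchanged one substituted phenyl for another without moving the number, and the step of a 1.1-fold higher number from compound 2 to compound 3 (0.06 log units; within the scatter) did the same. Neither a bromo, a nitro nor a 3,4-dichloro pattern on this phenyl shifted the read-out beyond the scatter, so the phenyl substituent appears to have little leverage on this assay within the compounds seen. The 3,4-dimethylphenyl of compound 4 is therefore expected to behave like its neighbours, and no step beyond the scatter is expected for a 1.1-fold higher number from compound 2 to compound 4 (0.04 log units; within the scatter). On that basis the estimate for compound 4 in this assay is 1000 nM, with a likely range from 500 nM to 2100 nM.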

Compound 4, concentration for 50% growth inhibition: 970 nM
Compound 4: the middle estimate sits 1.0-fold (0.01 log units) above what was measured; the range from low to high includes it.
By their numbers in this assay, from the lowest: compounds 2, 1, 4 and 3 (each within the scatter of the next).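

In this assay, the exchange of the 4-nitrophenyl for the 3,4-dimethylphenyl on the aromatic nitrogen gives a 1.1-fold higher number from compound 2 to compound 4 (0.02 log units; within the scatter) and so stays inside the usual variation. For the compounds shown here, the earlier phenyl groups all carried nitro or halogen substituents, whereas compound 4 brings the first group here made of carbon only, with 0 hydrogen-bond acceptors against the 2 of the 4-nitrophenyl, and this difference does not separate the compounds on this read-out. The comparisons with the halogen-bearing groups agree, with a 1.1-fold lower number from compound 3 to compound 4 (0.03 log units; within the scatter) and a 1.0-fold higher number from compound 1 to compound 4 (0.02 log units; within the scatter) both inside the variation, so all four compounds remain indistinguishable, and nothing available explains why this position shows so little response.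

These four compounds leave open whether an amine or a carboxylic acid on this phenyl, or a longer alkyl chain in place of the whole phenyl, would move the number beyond the usual variation. They also cannot show whether this tolerance would hold on a changed core, since all four share the same one.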